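The compounds below may be only part of what the source reports. "The series", "measured", "known", "first", "only" and "open" are said of these compounds alone.

Compound 1 `Fc1ccccc1Nc1nc(-c2ccccn2)cs1` gives 45400 nM in a physicochemical assay for solubility, using the shake flask method, measured as kinetic solubility, at pH 7.4; a lower number here means a less soluble compound, a higher number a more soluble compound.
Compound 2 `COC(=O)c1cccc(-c2cnc(Nc3cccc(F)c3)o2)c1` gives only a limit in this assay, namely < 1000 nM.
Compound 3 `COC(=O)c1cccc(-c2cnc(Nc3ccc(F)cc3)o2)c1` likewise gives only a limit in this assay, namely < 1000 nM.

Compound 3 therefore stands at a limit rather than at a number, and one further value shown is a limit as well; both of these sit at the limit of < 1000 nM in this assay, at which 2 of the 3 values shown sit. For this reason the step that the two limits leave unreadable from compound 2 to compound 3 cannot be read in size.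

Compound 4 `NCc1cccc(-c2cnc(Nc3ccc(F)cc3)o2)c1` differs from compound 3 by aminomethyl in place of methoxycarbonyl on an aromatic carbon. Going by the values given here, no measured step contains this change, and the only measured step, the one just named, gives no size at all. The expectation for compound 4 in this assay therefore rests on nothing firmer than the limit at which compound 3 stands, and it is correspondingly wide. Compound 4 is estimated to give about 5000 nM in this assay, with a range from 500 nM to 80000 nM. The step of an at least 5.0-fold higher number from compound 3 to compound 4 (0.69 log units; beyond the scatter) that this estimate implies is an expectation only, open in both directions.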

Compound 4, solubility: 50800 nM
Estimate against measurement, compound 4: 10-fold (1.01 log units) below, and the stated range covers the measured number.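

In this assay, aminomethyl in place of methoxycarbonyl on this aromatic carbon, meta to a large group, gives an at least 50-fold higher number from compound 3 to compound 4 (1.70 log units; beyond the scatter). This is the only step shown with a readable size, as the step between compound 2 and compound 3, where the fluorine changes place, cannot be read. Its full size stays unknown, as compound 3 stands at a limit and not at a number: the limit of < 1000 nM in this assay, at which 2 of the 4 values shown sit.

The compounds shown leave open whether a carboxylic acid, a hydroxymethyl group or a longer aminoethyl chain on this same carbon would give a number like that of compound 4, so the part played by the amine itself remains unsettled. They also leave open whether the same change would give a step of this size with the 3-fluorophenyl group of compound 2.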